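This account rests on a few compounds, and the source may have more. Where it says the series, first, only, none or still open, it means among the compounds named here.

Compound 1 `CC(C)[C@H](NC(=O)COc1cccc2ccccc12)C(=O)N[C@@H](CC(=O)O)C(=O)COc1cccc2ccccc12` gives 19000 nM.
Compound 2 `CC(C)[C@H](NC(=O)COc1cccc2ccccc12)C(=O)N[C@@H](CC(=O)O)C(=O)COc1ccc(C(F)(F)F)cc1` gives 12300 nM.
Compound 3 `CC(C)[C@H](NC(=O)COc1cccc2ccccc12)C(=O)N[C@@H](CC(=O)O)C(=O)COc1ccc(F)c(F)c1` gives 16200 nM.

In a functional assay with Homo sapiens as the target (on this read-out lower numbers stand for stronger inhibition and higher numbers for weaker inhibition), compound 2 sits within the usual scatter of both other measured compounds, as the steps of a 1.5-fold lower number from compound 1 to compound 2 (0.19 log units; within the scatter) and a 1.3-fold higher number from compound 2 to compound 3 (0.12 log units; within the scatter) show. Compound 4 `CC(C)[C@H](NC(=O)COc1cccc2ccccc12)C(=O)N[C@@H](CC(=O)O)C(=O)COc1c(F)c(F)cc(F)c1F` carries 2,3,5,6-tetrafluorophenyl in place of 4-(trifluoromethyl)phenyl on an oxygen on a saturated carbon. The three measured steps, a 1.5-fold lower number from compound 1 to compound 2 (0.19 log units; within the scatter), a 1.2-fold lower number from compound 1 to compound 3 (0.07 log units; within the scatter) and a 1.3-fold higher number from compound 2 to compound 3 (0.12 log units; within the scatter), all exchange the aromatic group on that same oxygen, and none of them moves the number beyond the scatter. A further exchange of the same kind is therefore expected to produce no step beyond the scatter in this assay, in either direction. Compound 4 is expected to give 14000 nM, within 6000 nM to 32000 nM. That estimate for compound 4 means a 1.1-fold higher number from compound 2 to compound 4 (0.06 log units; within the scatter).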

Compound 4, half-maximal inhibitory concentration: 6250 nM
Compound 4: the middle estimate sits 2.2-fold (0.35 log units) above what was measured; measured number inside the range.
By their numbers in this assay, from the lowest: compounds 4, 2, 3 and 1 (each within the scatter of the next, the first and the last beyond it).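

On the oxygen on a saturated carbon, the aromatic group can after all shift the number beyond the scatter in this assay: with 2,3,5,6-tetrafluorophenyl there is a 2.6-fold lower number from compound 3 to compound 4 (0.41 log units; beyond the scatter) and a 3.0-fold lower number from compound 1 to compound 4 (0.48 log units; beyond the scatter), both modest. The exchange for 4-(trifluoromethyl)phenyl, with a 2.0-fold lower number from compound 2 to compound 4 (0.29 log units; within the scatter), stays within the scatter, so compound 4 separates from compound 1 and compound 3 but not from compound 2. Nothing available here accounts for this difference.

Going by these compounds, it remains open whether an amine or a carboxylic acid on the phenyl ring would lower the number further. Also open, on these data alone, is whether a saturated ring such as cyclohexyl on that oxygen would keep it in this range.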